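A few compounds are considered here, and "the series" means these few. Any claim that something is new, unique, unknown or untested is made for them only; others in the source may bear on it.

Of the compounds shown here, three have so far been tested in a functional assay on NCI-H1975 cells (Homo sapiens) for antiproliferative activity, read by CCK-8 assay, with a stated time of 72 h; a higher number here means a weaker inhibitor of growth, a lower number a stronger inhibitor of growth. Compound 1, `CC[C@@H]1C(=O)N(C)c2cnc(-n3ccc4cc(F)ccc43)nc2N1C1CCCC1`, gives 46500 nM, the highest of the three numbers. Compound 2, `CCCCNS(=O)(=O)c1ccc(Nc2ncc3c(n2)N(c2ccn(C)n2)C(CC)C(=O)N3C)cc1`, gives 4120 nM, and compound 3, `CCC1C(=O)N(C)c2cnc(-n3ccc4cc(C(=O)NC(C)C)ccc43)nc2N1c1ccn(C)n1`, gives 12200 nM; both gaps to compound 1 lie beyond the usual scatter. Compound 4, `CC[C@@H]1C(=O)N(C)c2cnc(-n3ccc4cc(C(=O)NCC(C)C)ccc43)nc2N1C1CCCC1`, has not yet been measured. It differs from compound 1 in one place: isobutylcarbamoyl in place of fluoro on an aromatic carbon. Within the data shown here, no measured pair shows this change on its own. Compound 3 also carries a carbamoyl group, though with a different group on the shared core, and its number of 12200 nM is lower than that of compound 1, 46500 nM. A lowering step beyond the scatter is therefore expected, a 3.1-fold lower number from compound 1 to compound 4 (0.49 log units; beyond the scatter). Compound 4 is estimated at 15000 nM, with a likely range from 4000 nM to 50000 nM.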

Compound 4, concentration for 50% growth inhibition: "not active" (no number reported)
For compound 4 the study gives words and no number, so the estimate cannot be set against anything.
By their numbers in this assay, from the lowest: compound 2; then compound 3; then compound 1.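

Compound 4 is described in words only in this assay, so no step from compound 1 to compound 4 can be read, and nothing available explains this result. As far as these compounds go, how far isobutylcarbamoyl in place of fluoro shifts the number on the shared core remains open.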